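The source may hold more compounds than are shown below. What is called first, only, known or untested is meant among the compounds shown, and "the series" means these compounds.

Measured compounds in a functional assay on HT-29 cells (Homo sapiens) for inhibition, read by MTT assay, with a stated time of 72 h; a higher number here means a weaker inhibitor, a lower number a stronger inhibitor:

Compound 1 `COc1cc2c(Oc3ccc(NC(=O)c4nn(-c5ccccc5)c(=O)cc4C)cc3F)ccnc2cc1OCCCN1CCCC1` gives 220 nM.
Compound 2 `COc1cc2c(Oc3ccc(NC(=O)c4nn(-c5ccccc5C)c(=O)cc4C)cc3F)ccnc2cc1OCCCN1CCCC1` gives 1400 nM.
Compound 3 `COc1cc2c(Oc3ccc(NC(=O)c4nn(-c5ccccc5C)c(=O)cc4C)cc3F)ccnc2cc1OCCCN1CCC(C)CC1` gives 2810 nM.

Compound 2 sits second highest of the three numbers: its closest neighbour is compound 3, reached by a 2.0-fold higher number from compound 2 to compound 3 (0.30 log units; within the scatter), and it stands furthest from compound 1, which gives the lowest number of the set. The unmeasured compound 4 `COc1cc2c(Oc3ccc(NC(=O)c4nn(-c5ccccc5C(F)(F)F)c(=O)cc4C)cc3F)ccnc2cc1OCCCN1CCCC1` differs from compound 2 in one place: trifluoromethyl in place of methyl on an aromatic carbon, so the 2-methylphenyl of compound 2 becomes 2-(trifluoromethyl)phenyl. Within the data shown here, the only measured step that touches this part of the molecule is a 6.4-fold higher number from compound 1 to compound 2 (0.80 log units; beyond the scatter), where putting a methyl onto that aromatic carbon gave a weaker inhibitor. Among the measured compounds shown here, no measured pair shows what a trifluoromethyl does there, so the direction is inferred from that single step. The expectation is a further, modest weakening, a 1.8-fold higher number from compound 2 to compound 4 (0.25 log units; within the scatter), within this assay, with a fair chance of no change beyond the scatter. Compound 4 is therefore estimated at 2500 nM, with a range from 900 nM to 7000 nM.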

Compound 4, half-maximal inhibitory concentration: 140 nM
The estimate for compound 4 lay 18-fold (1.25 log units) above the measured number; the measured number lies below the stated range.
By their numbers in this assay, from the lowest: compounds 4 and 1 (each within the scatter of the next); then compounds 2 and 3 (each within the scatter of the next).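

In this assay, the change from 2-methylphenyl to 2-(trifluoromethyl)phenyl gives a 10-fold lower number from compound 2 to compound 4 (1.00 log units; beyond the scatter), so a group on this aromatic carbon can also strengthen inhibition, which the earlier step with methyl alone could not show. Set against hydrogen on the same carbon, trifluoromethyl gives a 1.6-fold lower number from compound 1 to compound 4 (0.20 log units; within the scatter), which lies within the scatter, so among compounds 1, 2 and 4 only methyl stands apart and the number does not follow the heavy-atom count of the group. Nothing available here explains why methyl and trifluoromethyl part so sharply on this carbon.

Still open, as far as these compounds go, is whether a chlorine, a methoxy or a nitrile on this carbon would follow methyl or trifluoromethyl. Also open, from the compounds shown here alone, is whether the trifluoromethyl result holds alongside the 4-methylpiperidin-1-yl group of compound 3.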